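A few compounds are considered here, and "the series" means these few. Any claim that something is new, unique, unknown or untested is made for them only; others in the source may bear on it.

Two compounds from this series have been run in a functional assay on OVCAR-8 cells (Homo sapiens) for inhibition, read by sulforhodamine B assay, with a stated time of 48 h; on this read-out lower numbers stand for higher toxicity in this test and higher numbers for lower toxicity in this test. Compound 1 `O=C(Nc1cccc(-n2cc(-c3ccncc3)c(-c3ccc(Cl)c(O)c3)n2)c1)Nc1cccc(C(F)(F)F)c1` reaches only a limit there, giving > 32500 nM in this assay. Compound 2 `COc1cc(-c2nn(-c3cccc(NC(=O)c4cccc(C(F)(F)F)c4)c3)cc2-c2ccncc2)ccc1Cl` likewise shows only a limit, > 50000 nM in this assay. Both values shown thus sit at limits, and neither carries a number. Compound 3 `COc1cc(-c2nn(-c3cccc(NC(=O)c4ccc(Cl)c(C(F)(F)F)c4)c3)cc2-c2ccncc2)ccc1Cl` differs from compound 2 by chloro in place of hydrogen on an aromatic carbon. Going by the values given here, no measured step exists to gauge this change, so no shift beyond the usual scatter is expected. The step of a number no higher from compound 2 to compound 3 (the limit leaves the size open) is estimated as essentially none. Compound 3 is accordingly expected near 50000 nM, within 20000 nM to 100000 nM, most likely again reported as a limit.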

Compound 3, concentration lethal to 50% of the cells: > 32500 nM
Compound 3 gave a limit, no number; the forecaster's own chance of this, stated with the estimate: 80%; the middle value lies beyond the limit too.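

Compound 2 and compound 3 both stand at limits in this assay, and the step between them cannot be read. As far as these compounds go, whether 4-chloro-3-(trifluoromethyl)phenyl and 3-(trifluoromethyl)phenyl differ at all in this assay remains open.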